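The compounds below may be only part of what the source reports. "The series", "measured", "known", "first", "only" and "open" are said of these compounds alone.

Measured in a functional assay on KYSE-70 cells for antiproliferative activity against KYSE-70 cell line (Homo sapiens), read by MTT assay, with a stated time of 72 h; a lower number here means a stronger inhibitor, a higher number a weaker inhibitor:
compound 1 `CC(C)(C)c1ccc(-c2ccc3c(C(=O)Nc4cccc(F)c4)cc(=O)[nH]c3c2)cc1`: > 20000 nM (a limit)
compound 2 `O=C(Nc1cccc(F)c1)c1cc(=O)[nH]c2cc(C3CC3)ccc12`: > 20000 nM (a limit)

Compound 2 gives > 20000 nM, which is a limit and not a number. It has no readable position in the series, and the same holds for the other measured compound: the limit of > 20000 nM in this assay, at which 2 of the 2 values shown sit.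

The next change leads to compound 3 `O=C(Nc1cccc(F)c1)c1cc(=O)[nH]c2cc(-c3ccncc3)ccc12`: pyridin-4-yl in place of cyclopropyl on an aromatic carbon. In words, pyridin-4-yl takes the place of cyclopropyl on an aromatic carbon of the shared core.

Within the data shown here, only one measured step bears on this place, a step that the two limits leave unreadable from compound 1 to compound 2. It offers no size to carry forward. It does show that compound 1, with 4-(tert-butyl)phenyl, and compound 2, with cyclopropyl, both end at a limit in this assay. Among the measured compounds shown here, no measured compound carries pyridin-4-yl, so the data support no direction of change. The working expectation is no gain beyond the scatter, with a report of a limit being the likeliest outcome.

The expected step is an at least 1.1-fold lower number from compound 2 to compound 3 (0.04 log units; that floor lies within the scatter).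

The estimate for compound 3 is 18000 nM, with an expected range from 6000 nM to 40000 nM.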

Compound 3, half-maximal inhibitory concentration: > 20000 nM
Compound 3: only a limit was reported (the forecaster's own chance of this, stated with the estimate: 70%); middle value at least 1.1-fold (0.04 log units) away from the limit.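

In this assay compound 3 gives > 20000 nM, which is a limit and not a number. The steps to compound 3 from compound 1 and compound 2 therefore cannot be read: the limit of > 20000 nM in this assay, at which 3 of the 3 values shown sit.

Going by these compounds, whether pyridin-4-yl, cyclopropyl and 4-(tert-butyl)phenyl differ at all in this assay stays open, as does whether any group at this place on the shared core gives a readable value.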